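This account rests on a few compounds, and the source may have more. Where it says the series, first, only, none or still open, it means among the compounds named here.

Series notes. The shared core carries a substituted phenyl on an amide-type nitrogen in a ring; three members have been run in a functional assay on HEK293 cells (Homo sapiens) for cytotoxicity; on this read-out lower numbers stand for higher toxicity in this test and higher numbers for lower toxicity in this test. Compound 1 `COc1ccc([C@H]2CC(=O)N(c3ccc(N)cc3)C2)cc1OC1CCCC1` bears a 4-aminophenyl on that nitrogen. In this assay compound 1 reaches only a limit of the assay, > 10000 nM. Compound 2 `COc1ccc([C@H]2CC(=O)N(c3cccc(S(C)(=O)=O)c3)C2)cc1OC1CCCC1` bears 3-(methylsulfonyl)phenyl instead. For compound 2 this assay likewise reports a limit, > 10000 nM, not a number. Compound 3 `COc1ccc([C@H]2CC(=O)N(c3ccc(S(C)(=O)=O)cc3)C2)cc1OC1CCCC1` is the 4-(methylsulfonyl)phenyl isomer. Compound 3 also stops at a limit, > 10000 nM. Compound 2 thus stands with both neighbours at the limit of > 10000 nM in this assay, at which 3 of the 3 values shown sit, and none of the steps can be sized: a step that the two limits leave unreadable from compound 1 to compound 2, a step that the two limits leave unreadable from compound 2 to compound 3, nor the direct exchange of the amino group, a step that the two limits leave unreadable from compound 1 to compound 3. Compound 4 `COc1ccc([C@H]2CC(=O)N(c3cccc(NS(=O)(=O)c4ccc(F)cc4)c3)C2)cc1OC1CCCC1` is next to be measured. It differs from compound 2 in one place: ((4-fluorophenyl)sulfonyl)amino in place of methylsulfonyl on an aromatic carbon. Both steps touching compound 2 are unreadable, so no direction beyond the scatter can be drawn from them, and nothing measured here ties a change of this kind to a shift in this assay. The expected step is a step that the limit leaves unreadable from compound 2 to compound 4, within the scatter. Compound 4 is therefore estimated at 12000 nM, with a range from 3000 nM to 50000 nM, and a limit rather than a number remains the likelier outcome.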

Compound 4, half-maximal cytotoxic concentration: > 10000 nM
Compound 4 gave a limit, no number; the forecaster's own chance of this, stated with the estimate: 60%; the middle value lies beyond the limit too.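

In this assay compound 4 gives only a limit, > 10000 nM, and, as compound 2 also stands at a limit, the step between compound 2 and compound 4 cannot be read. The compounds shown leave open whether any of these exchanges on the shared core shifts the read-out at all, since all remain at one limit: the limit of > 10000 nM in this assay, at which 4 of the 4 values shown sit.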